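Rho kinase series: isoxazole amide to aminomethylphenyl amide

The compounds below may be only part of what the source reports. "The series", "measured", "known", "first", "only" and "open" are said of these compounds alone.

Measured compounds:
compound 1 `CC(C)(C)c1ccc(C(=O)Nc2cccc(NC(=O)COc3ccc4c(=O)ccoc4c3)c2)cc1` gives 34 nM
compound 2 `Cc1cc(C(=O)Nc2cccc(NC(=O)COc3ccc4c(=O)ccoc4c3)c2)ccc1C(F)(F)F` gives 43 nM
compound 3 `Cc1cc(C(=O)Nc2cccc(NC(=O)COc3ccc4c(=O)ccoc4c3)c2)no1` gives 5 nM

All three share the same core and differ only in the group on the carbonyl carbon of the outer amide. In an assay on isolated protein for inhibition of Rho-associated protein kinase 2 (Homo sapiens), read by scintillation counting, radiometric assay and 33P incorporation, with a stated time of 40 min, in the presence of a further agent that is not named here (on this read-out lower numbers stand for stronger inhibition and higher numbers for weaker inhibition), compound 3 stands lowest of the three numbers. The step of a 6.8-fold lower number from compound 1 to compound 3 (0.83 log units; beyond the scatter) and the step of an 8.6-fold lower number from compound 2 to compound 3 (0.93 log units; beyond the scatter) both lie beyond the scatter, whereas the step of a 1.3-fold higher number from compound 1 to compound 2 (0.10 log units; within the scatter) lies within it.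

Compound 4 `NCc1ccc(C(=O)Nc2cccc(NC(=O)COc3ccc4c(=O)ccoc4c3)c2)cc1` is not yet measured. The change from compound 3 is 4-(aminomethyl)phenyl in place of 5-methyl-1,2-oxazol-3-yl on a carbonyl carbon. This reverses the direction of the measured steps: an aromatic six-membered carbon ring returns in place of the five-membered ring with two hetero atoms, now carrying an aminomethyl group, for which the measured compounds offer no direct comparison. The two steps that bear on it, from compound 1 and compound 2 to compound 3, both gave lower numbers on moving to the isoxazole; going back to a phenyl ring is therefore expected to give a higher number, of a size comparable to those steps, although the aminomethyl group adds uncertainty. Compound 4 is expected to show the step of a 6.0-fold higher number from compound 3 to compound 4 (0.78 log units; beyond the scatter). The estimate for compound 4 is 30 nM, with a range from 8 nM to 110 nM.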

Compound 4, half-maximal inhibitory concentration: 66 nM
Estimate against measurement, compound 4: 2.2-fold (0.34 log units) below; the range from low to high includes it.
By their numbers in this assay, from the lowest: compound 3; then compounds 1, 2 and 4 (each within the scatter of the next).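

In this assay, going by these compounds alone, the change from 5-methyl-1,2-oxazol-3-yl to 4-(aminomethyl)phenyl on the carbonyl carbon gives a 13-fold higher number from compound 3 to compound 4 (1.12 log units; beyond the scatter), the largest step so far, and compound 3 remains apart from all three phenyl amides. Aminomethyl in place of tert-butyl on the aromatic carbon gives a 1.9-fold higher number from compound 1 to compound 4 (0.29 log units; within the scatter), and the comparison with the methyl- and trifluoromethyl-bearing phenyl group gives a 1.5-fold higher number from compound 2 to compound 4 (0.19 log units; within the scatter), so among compounds 1, 2 and 4 the three different phenyl substitution patterns read alike, even though the 4-(aminomethyl)phenyl group brings a hydrogen-bond donor. No supporting measurement is available to account for these readings.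

The compounds shown do not separate the contribution of the ring from that of its substituent, since the five-membered ring appears only with methyl and the aminomethyl group only on phenyl. A 5-(aminomethyl)-1,2-oxazol-3-yl group or an unsubstituted phenyl group on the same carbonyl carbon would address this, and a longer aminoalkyl chain or a carboxylic acid in place of aminomethyl would show whether the phenyl series stays this flat.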